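Aryl amide variation on a shared core: compound 4

The source may hold more compounds than are shown below. What is called first, only, known or untested is meant among the compounds shown, and "the series" means these compounds.

Compound 1 `CCN1CCN(c2cc(C)c3cc(NC(=O)c4ccc[nH]4)ccc3n2)CC1` holds the lowest of the three numbers in a functional assay on SK-BR-3 cells (Homo sapiens) for antiproliferative activity, read by MTT assay, with a stated time of 72 h (a higher number here means a weaker inhibitor, a lower number a stronger inhibitor), giving 13200 nM, though every gap to it lies within the scatter. Compound 2 `CCN1CCN(c2cc(C)c3cc(NC(=O)c4ccccc4)ccc3n2)CC1` gives 18400 nM and compound 3 `CCN1CCN(c2cc(C)c3cc(NC(=O)c4ccccc4OC)ccc3n2)CC1` gives 15700 nM; the steps of a 1.4-fold higher number from compound 1 to compound 2 (0.14 log units; within the scatter) and a 1.2-fold higher number from compound 1 to compound 3 (0.08 log units; within the scatter) stay within the scatter, as does a 1.2-fold lower number from compound 2 to compound 3 (0.07 log units; within the scatter). Compound 4 `CCN1CCN(c2cc(C)c3cc(NC(=O)c4ccc(OC)cc4)ccc3n2)CC1` differs from compound 1 by 4-methoxyphenyl in place of 1H-pyrrol-2-yl on a carbonyl carbon. The two earlier swaps away from the same group bear directly on this change and moved nothing beyond the scatter, and the methoxy step likewise showed no effect. For compound 4, therefore, no shift beyond the scatter is expected, the expected step being a 1.1-fold higher number from compound 1 to compound 4 (0.06 log units; within the scatter). The estimated value for compound 4 in this assay is 15000 nM, with a range from 7000 nM to 32000 nM.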

Compound 4, half-maximal inhibitory concentration: 9000 nM
Compound 4: middle estimate off by 1.7-fold (0.22 log units), on the high side; measured number inside the range.
By their numbers in this assay, from the lowest: compounds 4, 1, 3 and 2 (each within the scatter of the next, the first and the last beyond it).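

Among the compounds shown here, on the carbonyl carbon, methoxy in place of hydrogen now gives the first step beyond the scatter in this assay, a modest one (a 2.0-fold lower number from compound 2 to compound 4 (0.31 log units; beyond the scatter)), whereas 2-methoxyphenyl stayed within the scatter of phenyl. The other two steps stay within the scatter: 4-methoxyphenyl for 2-methoxyphenyl (a 1.7-fold lower number from compound 3 to compound 4 (0.24 log units; within the scatter)) and for 1H-pyrrol-2-yl (a 1.5-fold lower number from compound 1 to compound 4 (0.17 log units; within the scatter)). No evidence at hand accounts for this result. Open, from the compounds shown here alone, is whether a 4-ethoxyphenyl, 4-aminophenyl or 4-carboxyphenyl on the same carbonyl carbon would move the number further from that of compound 2.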